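This account rests on a few compounds, and the source may have more. Where it says the series, first, only, none or still open, it means among the compounds named here.

Compound 1 `COC(=O)N1N=C(c2ccccc2)CC1c1cc(OC)c(OC)c(OC)c1` is the reference point of this small set. In a functional assay on A549 cells (Homo sapiens) for antiproliferative activity, read by MTT assay, with a stated time of 48 h (on this read-out lower numbers stand for stronger inhibition of growth and higher numbers for weaker inhibition of growth), compound 1 gives 2880 nM, the only numbered result among the three measured compounds. Compound 2 `CCCOC(=O)N1N=C(c2ccccc2)CC1c1cc(OC)c(OC)c(OC)c1` gives only a limit in this assay, > 10000 nM. Compound 3 `COc1cc(C2CC(c3ccccc3)=NN2C(=O)OCc2ccccc2)cc(OC)c1OC` likewise gives only a limit, > 10000 nM. The two measured steps, an at least 3.4-fold higher number from compound 1 to compound 2 (0.54 log units; beyond the scatter) and an at least 3.4-fold higher number from compound 1 to compound 3 (0.54 log units; beyond the scatter), both alter the carbamate ester, and what they share is the limit of > 10000 nM in this assay, at which 2 of the 3 values shown sit.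

Compound 4 `COC(=O)N1N=C(c2cccc(O)c2)CC1c1cc(OC)c(OC)c(OC)c1` keeps the methyl carbamate of compound 1 and changes only the phenyl ring: hydroxy in place of hydrogen on an aromatic carbon, read one bond further out as phenyl to 3-hydroxyphenyl. Within the data shown here, neither measured step touches this ring, so no measured step bears on the change, and no direction can be read from the data. The expected step is therefore one within the scatter, a 1.2-fold lower number from compound 1 to compound 4 (0.06 log units; within the scatter), carried with a wide range. Compound 4 is estimated at 2500 nM, between 600 nM and 9000 nM.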

Compound 4, concentration for 50% growth inhibition: 3170 nM
Compound 4: middle estimate off by 1.3-fold (0.10 log units), on the low side, and the stated range covers the measured number.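

In this assay, hydroxy in place of hydrogen on an aromatic carbon gives a 1.1-fold higher number from compound 1 to compound 4 (0.04 log units; within the scatter), so compound 1 and compound 4 cannot be told apart. Among these compounds, this is the first reading on the phenyl ring, and it shows that this position takes a group with a hydrogen-bond donor and a hydrogen-bond acceptor with no readable change in growth inhibition. Compound 2 and compound 3, both changed at the carbamate ester, remain limits of the assay rather than numbers: the limit of > 10000 nM in this assay, at which 2 of the 4 values shown sit.

On these data alone, the step between compound 2 and compound 3 cannot be read, so the order of those two ester groups stays unknown. As far as these compounds go, whether this tolerance extends to other groups at this aromatic carbon, such as an amine, a methoxy group or a carboxylic acid, also stays open.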